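Swapping a methylnaphthalenyl for a bromonaphthalenyl in a sulfonamide series

The compounds below may be only part of what the source reports. "The series", "measured", "known", "first", "only" and "open" are said of these compounds alone.

Measured so far:
- compound 1, `Cc1cc(S(N)(=O)=O)ccc1NC(=O)COc1ccc(F)cc1Oc1ccc2ccccc2c1`: 68600 nM
- compound 2, `Cc1cc(S(N)(=O)=O)ccc1NC(=O)COc1ccc(Cl)cc1Oc1ccc2cc(Br)ccc2c1`: 31300 nM
- compound 3, `Cc1cc(S(N)(=O)=O)ccc1NC(=O)COc1ccc(F)cc1Oc1cc2ccccc2cc1C`: 66900 nM

In an ADME assay on C8166 cells (Homo sapiens) for cytotoxicity, read by MTT assay (on this read-out higher numbers stand for lower toxicity in this test and lower numbers for higher toxicity in this test), compound 3 stands second highest of the three numbers, close to compound 1 and furthest from compound 2. Among the compounds with values here, the only single change measured, a 1.0-fold lower number from compound 1 to compound 3 (0.01 log units; within the scatter), lies within the scatter. Compound 4, `Cc1cc(S(N)(=O)=O)ccc1NC(=O)COc1ccc(F)cc1Oc1ccc2cc(Br)ccc2c1`, differs from compound 3 by 6-bromonaphthalen-2-yl in place of 3-methylnaphthalen-2-yl on an oxygen on an aromatic ring. Within the data shown here, no measured step bears on this exact change; compound 2 carries the same bromonaphthalenyl group, together with a different halogen, and gives a lower number than compound 1. For compound 4 a modest step of a 1.5-fold lower number from compound 3 to compound 4 (0.17 log units; within the scatter) towards lower numbers is therefore expected, with 45000 nM estimated, between 22000 nM and 90000 nM.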

Compound 4, half-maximal cytotoxic concentration: > 357000 nM
Compound 4: no number, only a limit (the forecaster's own chance of this, stated with the estimate: 10%); middle value at least 7.9-fold (0.89 log units) from the limit.
By their numbers in this assay, from the lowest: compound 2; then compounds 3 and 1 (each within the scatter of the next). At a limit, above all of these: compound 4.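

In this assay compound 4 reads only as a limit of the assay, not as a number: the limit of > 357000 nM in this assay, at which 1 of the 4 values shown sits. Even so, the bromo group on the naphthalene clearly raises the number, with an at least 5.2-fold higher number from compound 1 to compound 4 (0.71 log units; beyond the scatter) and, against the methyl group, an at least 5.3-fold higher number from compound 3 to compound 4 (0.72 log units; beyond the scatter). Fluoro in place of chloro gives an at least 11-fold higher number from compound 2 to compound 4 (1.05 log units; beyond the scatter), so the low number of compound 2 cannot be laid on the bromonaphthalenyl group alone. Going by these compounds, the true size of these steps stays unknown while compound 4 sits at a limit. On these data alone, it also remains open whether an amine or a carboxylic acid in place of the bromo would keep the number this high.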